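Replacing a Formyl Group in a Red Blood Cell Assay

This account rests on a few compounds, and the source may have more. Where it says the series, first, only, none or still open, it means among the compounds named here.

Of the compounds shown here, two have been measured in an ADME assay on cells (Erythrocyte, Homo sapiens), read by spectrophotometry and hemolysis, with a stated time of 24 h; a lower number here means a stronger inhibitor, a higher number a weaker inhibitor. Compound 1 `O=Cc1ccccc1OCc1ccc2no[n+]([O-])c2c1` reads > 100 uM, which is a limit of the assay and not a number. Among the measured compounds shown here, compound 2 `CC1(C)[N+]([O-])=c2ccc(COc3ccc(C=O)cc3)cc2=[N+]1[O-]` gives 65 uM, the only true number available, so there is no second number to set it against.

The next structure is compound 3 `CC1(C)[N+]([O-])=c2ccc(COc3ccc(/C=N/NC(N)=O)cc3)cc2=[N+]1[O-]`. It keeps all of compound 2 except at one place, on an aromatic carbon of a six-membered aromatic ring of carbon only, para to a large group. There the formyl group leaves and a larger group with no ring enters: a group of 6 heavy atoms (2 carbon, 3 nitrogen, 1 oxygen; no ring) in place of a group of 2 heavy atoms (1 carbon, 1 oxygen; no ring), on an aromatic carbon.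

For the measured compounds named here, no pair of measured compounds differs in just one place, so the size of this change has no measured precedent in this assay. Going by the values given here, the only anchor is compound 2 at 65 uM. The expected change is small, within the usual scatter, and is estimated as a 1.2-fold higher number from compound 2 to compound 3 (0.09 log units; within the scatter). A result reported only as a limit would also fit this expectation. For compound 3 the estimated value is 80 uM, with an expected range from 30 uM to 200 uM.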

Compound 3, concentration for 50% inhibition: > 200 uM
Compound 3 ended at the assay's limit (the forecaster's own chance of this, stated with the estimate: 40%); at least 2.5-fold (0.39 log units) between middle value and limit.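

In this assay, among the compounds shown here, this is the first change with a readable size at this place, on an aromatic carbon para to a large group: an at least 3.0-fold higher number from compound 2 to compound 3 (0.48 log units; beyond the scatter). Replacing the formyl group with the larger group with no ring therefore does matter here, and the number moves towards a weaker inhibitor rather than staying within the usual scatter. The reading for compound 3 is a limit of the assay and not a number, so the step gives only a lower bound and the true size of the change stays unknown: the limit of > 200 uM in this assay, at which 1 of the 3 values shown sits.

With a single replacement at this place, the larger size of the entering group cannot be separated from its added nitrogen atoms, hydrogen-bond donors or second double bond. A nitrile, a carboxylic acid or a simple amine on the same carbon would help show which of these features goes with the higher number, and whether any replacement of the formyl group can keep or lower the value of compound 2.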